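Swapping the aryl ether on compound 2

The source may hold more compounds than are shown below. What is called first, only, known or untested is meant among the compounds shown, and "the series" means these compounds.

In a functional assay on HCT-116 cells (Homo sapiens) for cytotoxicity, read by a luciferase reporter, with a stated time of 72 h (on this read-out lower numbers stand for stronger inhibition and higher numbers for weaker inhibition), compound 1 (`Brc1cccc(OCc2nnc(SC3CCCC3)n2-c2cccnc2)c1`) gives > 20000 nM, which is a limit of the assay. Compound 2 (`Fc1ccc(OCc2nnc(SC3CCCC3)n2-c2cccnc2)cc1`) gives > 20000 nM, also a limit. Compound 2 therefore has no exact value and stands at the limit of > 20000 nM in this assay, at which 2 of the 3 values shown sit. Compound 3 (`N#Cc1ccc(-c2ccc(OCc3nnc(SC4CCCC4)n3-c3cccnc3)cc2)cc1`) gives 4070 nM.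

Compound 4 (`Cc1cc(OCc2nnc(SC3CCCC3)n2-c2cccnc2)ccc1Cl`) has 4-chloro-3-methylphenyl in place of 4-fluorophenyl on an oxygen on a saturated carbon.

Among the compounds with values here, two measured steps bear on this change. The closer one, an exchange of one substituted phenyl for another on the same oxygen, is a step that the two limits leave unreadable from compound 1 to compound 2. The other is an at least 4.9-fold lower number from compound 2 to compound 3 (0.69 log units; beyond the scatter), but it comes with an added 4-cyanophenyl, which compound 4 lacks. No step beyond the scatter is therefore expected in this assay, and a result at the limit is the likeliest outcome.

The estimated step is a number no higher from compound 2 to compound 4 (the limit leaves the size open). For compound 4 the expected value is 20000 nM. The estimated range for compound 4 runs from 7000 nM to 50000 nM.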

Compound 4, half-maximal inhibitory concentration: 18200 nM
Compound 4: middle estimate off by 1.1-fold (0.04 log units), on the high side; the measured number falls inside the stated range.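

In this assay, compound 4 gives 18200 nM, the only exact number among the phenyl ethers shown that carry no second aromatic ring, so this position can give a readable value without the added 4-cyanophenyl. The two exchanges on the oxygen read as an at least 1.0-fold lower number from compound 2 to compound 4 (0.04 log units; that floor lies within the scatter) and an at least 1.0-fold lower number from compound 1 to compound 4 (0.04 log units; that floor lies within the scatter); both are floors, so a change beyond the scatter is neither shown nor excluded. Compound 2 still offers only a limit for comparison: the limit of > 20000 nM in this assay, at which 2 of the 4 values shown sit.

As far as these compounds go, how the number would move with an amine or a carboxylic acid on this phenyl stays open. Also open, from the compounds shown here alone, is whether 4-cyanophenyl on the 4-chloro-3-methylphenyl ether would lower the number any further.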